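The source may hold more compounds than are shown below. What is called first, only, known or untested is meant among the compounds shown, and "the series" means these compounds.

Compound 3 `CC1=CC(=O)N(Nc2nc(-c3cccs3)ncc2C#N)C1=O` gives 5000 nM in a functional assay on Jurkat cells for inhibition of nuclear factor NF-kappa-B complex (Homo sapiens) (on this read-out lower numbers stand for stronger inhibition and higher numbers for weaker inhibition), the second highest of the three numbers shown: compound 1 `CCOC(=O)c1cnc(-n2nc(C)cc2C)nc1NN1C(=O)C=C(C)C1=O` gives 10000 nM, a gap within the scatter, while compound 2 `CC1=CC(=O)N(Nc2nc(-c3cccs3)ncc2-c2cc(C)no2)C1=O` gives 300 nM, well beyond it. Compound 4 `CC1=CC(=O)N(Nc2nc(-c3cccs3)ncc2C2=NCCO2)C1=O` differs from compound 3 by a group of 5 heavy atoms (3 carbon, 1 nitrogen, 1 oxygen; one five-membered non-aromatic ring with 2 hetero atoms) in place of a group of 2 heavy atoms (1 carbon, 1 nitrogen; no ring), on an aromatic carbon. Among the compounds with values here, the one measured step that bears on this position is a 17-fold higher number from compound 2 to compound 3 (1.22 log units; beyond the scatter), where cyano replaced 3-methyl-1,2-oxazol-5-yl on an aromatic carbon and the number rose sharply. The entering five-membered ring is, in what is counted, closer to that earlier ring group than to cyano, so a lower number is expected for compound 4, though a partial recovery, as the estimated step of a 4.2-fold lower number from compound 3 to compound 4 (0.62 log units; beyond the scatter) describes. Compound 4 is thus expected to give 1200 nM, in the range 300 nM to 5000 nM.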

Compound 4, half-maximal inhibitory concentration: 200 nM
Beside the measured number, compound 4's estimate is 6.0-fold (0.78 log units) above it; the measured number lies below the stated range.
By their numbers in this assay, from the lowest: compounds 4 and 2 (each within the scatter of the next); then compounds 3 and 1 (each within the scatter of the next).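

In this assay the change of cyano to the five-membered non-aromatic ring is a large gain, a 25-fold lower number from compound 3 to compound 4 (1.40 log units; beyond the scatter), so this aromatic carbon takes more than the partial recovery that the earlier ring group alone suggested. Against 3-methyl-1,2-oxazol-5-yl the ring shows a 1.5-fold lower number from compound 2 to compound 4 (0.18 log units; within the scatter), so among these compounds an aromatic ring is not needed here for the lower number. No measurement shown explains this gain. The compounds shown leave open how a carboxylic acid, an open-chain amide or a cyclopentyl ring would read on this aromatic carbon.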